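A few compounds are considered here, and "the series" means these few. Any claim that something is new, unique, unknown or untested is made for them only; others in the source may bear on it.

Measured so far in a functional assay on HCC827 cells (Homo sapiens) for inhibition, read by MTT assay, with a stated time of 48 h, tested at 10 uM; on this read-out higher numbers stand for more inhibition at the one concentration tested (going by the name of the read-out) and lower numbers for less inhibition:
compound 1 `Cc1ccc(Nc2cc(NC(=O)Nc3c(Cl)cccc3Cl)ncn2)cc1F`, 85.3%
compound 2 `COc1cc(NC(=O)Nc2cc(Nc3ccc(C)c(F)c3)ncn2)cc(OC)c1`, 72%
compound 3 `CCc1ccc(Nc2cc(NC(=O)Nc3c(Cl)cccc3Cl)ncn2)cc1`, 58%

Compound 2 stands second of the three in this assay: compound 1 lies higher by a gap beyond the scatter, and compound 3 lies lower by a gap of about the same size, also beyond the scatter. Within the data shown here, the only one-place step among the measured compounds is a number 27.3 percentage points lower from compound 1 to compound 3 (beyond the scatter), a modest loss on exchanging the aryl group carried on the nitrogen on the aromatic ring, though on a core that differs from compound 2 in the urea-side aryl group.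

Compound 4 `COc1cc(NC(=O)Nc2cc(Nc3ccc(OC)c(I)c3)ncn2)cc(OC)c1` differs from compound 2 in the same region: 3-iodo-4-methoxyphenyl in place of 3-fluoro-4-methylphenyl on a nitrogen on an aromatic ring. Among the measured compounds shown here, no measured pair isolates this exact exchange, so the step from compound 1 to compound 3 is the only guide, and it points to a change of modest size, downward, when this aryl group is varied. For compound 4 a drop of similar size is therefore expected, a number 14 percentage points lower from compound 2 to compound 4 (beyond the scatter), though a result within the scatter of compound 2 cannot be excluded. Compound 4 is estimated at 58%, with a range from 35% to 80%.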

Compound 4, a percentage reported as inhibition, at one concentration (the size of the read-out at that concentration, not a potency): 61.7%
Estimate against measurement, compound 4: 3.7 percentage points below; low and high end bracket the measured number.
By their numbers in this assay, from the lowest: compounds 3 and 4 (each within the scatter of the next); then compound 2; then compound 1.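

In this assay, 3-iodo-4-methoxyphenyl in place of 3-fluoro-4-methylphenyl on a nitrogen on an aromatic ring gives a number 10.3 percentage points lower from compound 2 to compound 4 (beyond the scatter), so this position now has a second downward step, on a core whose urea-side aryl group differs from that of compound 1. Both one-place exchanges away from 3-fluoro-4-methylphenyl lower the number and no listed pair goes against this, though the pattern rests on only two pairs. No measured evidence bears on the reason for this step.

The exchange alters the ring in two places together, so the contributions of iodo and methoxy cannot be read apart. Open too, as far as these compounds go, are how 3-iodo-4-methoxyphenyl behaves on the core of compound 1, and how an amine, a carboxylic acid or a longer chain on this aryl ring would fare.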